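The compounds below may be only part of what the source reports. "The series", "measured", "known", "first", "only" and "open" are said of these compounds alone.

Measured so far:
compound 1 `CC1CCN(C2CCN(S(=O)(=O)c3ccc(-c4ccccc4F)cc3)CC2)CC1`: 5 nM
compound 2 `CC1CCN(C2CCN(S(=O)(=O)c3sc(Cl)nc3C3CC3)CC2)CC1`: a limit of the assay, > 5000 nM

Among the measured compounds shown here, in a functional assay on DLD-1 cells (Homo sapiens) for antiproliferative activity, read by CellTiter-Glo, with a stated time of 72 h (on this read-out lower numbers stand for stronger inhibition and higher numbers for weaker inhibition), compound 1 gives 5 nM, the only number among the values shown. For the measured compounds named here, compound 2 returns only a limit of the assay, > 5000 nM; it is the one other value and sits at the limit of > 5000 nM in this assay, at which 1 of the 2 values shown sits. Going by the values given here, no step between measured compounds that differ in one place is available, so no measured change sets a scale for the series.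

Compound 3 `CC1CCN(C2CCN(S(=O)(=O)c3ccc(C(C)C)cc3)CC2)CC1` is not yet measured. Against compound 1 the change is isopropyl in place of 2-fluorophenyl on an aromatic carbon, the position being para to a large group. Among the compounds with values here, with no measured step to lean on, the expectation in this assay is a loss beyond the usual scatter, of moderate size, a 10-fold higher number from compound 1 to compound 3 (1.00 log units; beyond the scatter). Compound 3 is accordingly estimated at 50 nM, with a range from 8 nM to 400 nM.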

Compound 3, half-maximal inhibitory concentration: 685 nM
Compound 3: the middle estimate sits 14-fold (1.14 log units) below what was measured, outside the stated range (above it).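

In this assay, among the compounds shown here, the position para to a large group proves highly sensitive: isopropyl in place of 2-fluorophenyl on an aromatic carbon gives a 140-fold higher number from compound 1 to compound 3 (2.14 log units; beyond the scatter), the first measured step and a large one. The aromatic ring of carbon only with its fluorine therefore counts for much of the activity in this series, yet compound 3 still gives a measured number, 685 nM, so the change does not abolish activity in this assay. No measured property among the data accounts for the size of this step.

As far as these compounds go, whether the step follows from losing the ring or the fluorine stays open; plain phenyl and cyclohexyl at this place would separate the two. Also open, from the compounds shown here alone, is how an amine or a carboxylic acid on this aromatic carbon would read.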